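Swapping methylsulfanyl for butyl: what to expect

The compounds below may be only part of what the source reports. "The series", "measured", "known", "first", "only" and "open" are said of these compounds alone.

Measured so far in a functional assay on U-251 cells (Homo sapiens) for inhibition, read by sulforhodamine B assay, with a stated time of 72 h; on this read-out higher numbers stand for an effect only at larger amounts of compound and lower numbers for an effect already at smaller amounts:
compound 1 (`CCC(=O)Oc1cccc2ccc(/C=C/c3ccccc3[N+](=O)[O-])nc12`) gives 10100 nM
compound 2 (`CSc1ccc(C(=O)/C=C/c2ccc([N+](=O)[O-])o2)cc1`) gives 14200 nM
compound 3 (`CC(C)(C)c1ccc(C(=O)/C=C/c2ccc([N+](=O)[O-])o2)cc1`) gives 44500 nM

Compound 2 and compound 1 lie within the usual scatter of each other, so these two cannot be ranked. Compound 3 stands clearly apart from both. The next compound to be tested is compound 4 (`CCCCc1ccc(C(=O)/C=C/c2ccc([N+](=O)[O-])o2)cc1`). It differs from compound 2 in one place, with butyl in place of methylsulfanyl on an aromatic carbon.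

For the measured compounds named here, one measured step bears on this change, and it starts from the same compound and the same place. With tert-butyl in place of methylsulfanyl, the result is a 3.1-fold higher number from compound 2 to compound 3 (0.50 log units; beyond the scatter) and counts as modest. Going by the values given here, compound 1 has a different core and offers no comparable step. Butyl is not tert-butyl, and a single step is thin evidence, so only a cautious upward move is expected in this assay, smaller than that step and possibly lost in the scatter. The estimated change is a 1.9-fold higher number from compound 2 to compound 4 (0.28 log units; within the scatter) and should be read as a rough guide. Compound 4 is expected near the estimate (27000 nM), with an estimated range (11000 nM to 60000 nM).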

Compound 4, half-maximal effective concentration: 3900 nM
Compound 4: the middle estimate sits 6.9-fold (0.84 log units) above what was measured; measured number below the stated range.
By their numbers in this assay, from the lowest: compound 4; then compounds 1 and 2 (each within the scatter of the next); then compound 3.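

For the compounds shown here, the one earlier step at this position, on an aromatic carbon para to a large group, could have suggested that replacing methylsulfanyl with a carbon-only group weakens the effect in this assay, but butyl goes the other way, with a 3.6-fold lower number from compound 2 to compound 4 (0.56 log units; beyond the scatter) and so an effect at smaller amounts of compound. The two carbon-only groups also separate widely at this same place, with an 11-fold lower number from compound 3 to compound 4 (1.06 log units; beyond the scatter), which shows that the outcome of this change depends on which group enters and not merely on the loss of methylsulfanyl and its sulfur. Nothing shown gives a measured explanation for the gap between butyl and tert-butyl.

The compounds shown leave open whether a shorter chain such as ethyl or a longer chain such as hexyl would follow butyl, and how an amine or a carboxylic acid at the end of such a chain would compare. They also leave open whether compound 2, compound 3 and compound 4 would keep the same order in other cell types.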